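The source may hold more compounds than are shown below. What is called first, only, known or untested is meant among the compounds shown, and "the series" means these compounds.

Measured compounds:
compound 1 `CCOc1cccc(-c2ccc(CN(C(=O)C3CCCCC3)c3cccc(/C=C/C(=O)OC)c3)cc2)c1` — 147 nM
compound 2 `COC(=O)/C=C/c1cccc(N(Cc2ccc(Br)cc2)C(=O)C2CCCCC2)c1` — > 1000 nM
compound 3 `CCOC(=O)/C=C/c1ccc(CN(C(=O)C2CCCCC2)c2cccc(/C=C/C(=O)OC)c2)cc1` — > 1000 nM

In an assay on isolated protein with Bile acid receptor (Homo sapiens) as the target (on this read-out higher numbers stand for an effect only at larger amounts of compound and lower numbers for an effect already at smaller amounts), compound 1 gives 147 nM. For compound 2 the value > 1000 nM is a limit of the assay, not a number. For compound 3 the value > 1000 nM is likewise only a limit. Compound 3 therefore stands at the limit of > 1000 nM in this assay, at which 2 of the 3 values shown sit, and only compound 1 has a true number among the three. The step of an at least 6.8-fold higher number from compound 1 to compound 3 (0.83 log units; beyond the scatter) shows that exchanging the 3-ethoxyphenyl for the 2-(ethoxycarbonyl)ethenyl costs activity, and an at least 6.8-fold higher number from compound 1 to compound 2 (0.83 log units; beyond the scatter) shows the same loss when bromo takes its place. The step that the two limits leave unreadable from compound 2 to compound 3 cannot be read, since both ends are limits.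

Compound 4 `COC(=O)/C=C/c1cccc(N(Cc2ccc(-c3ccc(SC)cc3)cc2)C(=O)C2CCCCC2)c1` brings an aromatic ring back into that position: 4-(methylsulfanyl)phenyl in place of 2-(ethoxycarbonyl)ethenyl on an aromatic carbon. Because an at least 6.8-fold higher number from compound 1 to compound 3 (0.83 log units; beyond the scatter) was the loss on removing such a ring, the reverse move is expected to lower the number again, with an expected step of an at least 5.0-fold lower number from compound 3 to compound 4 (0.69 log units; beyond the scatter). Compound 4 is therefore estimated at 200 nM, in the range 60 nM to 800 nM.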

Compound 4, half-maximal effective concentration: 69 nM
Compound 4: the middle estimate sits 2.9-fold (0.46 log units) above what was measured, and the stated range covers the measured number.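

Putting 4-(methylsulfanyl)phenyl at this position restores activity in this assay, as an at least 14-fold lower number from compound 3 to compound 4 (1.16 log units; beyond the scatter) and an at least 14-fold lower number from compound 2 to compound 4 (1.16 log units; beyond the scatter) show, so the activity seen with an aromatic ring here is not tied to the 3-ethoxyphenyl group. The choice of ring substituent also matters, though less: a 2.1-fold lower number from compound 1 to compound 4 (0.33 log units; beyond the scatter). Compound 2 and compound 3 are known only through a limit of the assay, so the two large steps are minimum sizes, because their true end points lie beyond that limit: the limit of > 1000 nM in this assay, at which 2 of the 4 values shown sit.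

Still open, as far as these compounds go, is whether the ring alone accounts for the activity, or whether the group it carries is also needed. A plain phenyl would address that question, and a phenyl carrying a carboxylic acid or an amine would show how far the ring's substituent can be varied.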